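This account rests on a few compounds, and the source may have more. Where it says the series, first, only, none or still open, it means among the compounds named here.

Compound 1 `Nc1ccc(Nc2c(C(=O)NCc3ccc(F)cc3)nc(Br)c3cccnc23)cc1`: 4000 nM
Compound 2 `O=C(NCc1ccc(F)cc1)c1nc(Br)c2cccnc2c1NCc1ccc(F)cc1`: "not determined" (no result reported)

Within the data shown here, both compounds were taken into a functional assay on MCF7 cells (Homo sapiens) for cytotoxicity, read by MTT assay, with a stated time of 72 h (on this read-out higher numbers stand for weaker inhibition and lower numbers for stronger inhibition), but only one gave a number. Compound 2 stands at "not determined" (no result reported), so it offers no starting value for comparison. The only figure available comes from compound 1, at 4000 nM.

Compound 3 `O=C(NCCCNc1c(C(=O)NCc2ccc(F)cc2)nc(Br)c2cccnc12)c1ccccc1` is the next to be measured, and it keeps the shared core. The structural change is 2-benzamidoethyl in place of 4-fluorophenyl on a saturated chain carbon bound to a nitrogen on an aromatic ring.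

Among the measured compounds shown here, with no measured step to draw on, the size of this change in this assay cannot be read from the data. For the measured compounds named here, the only guide is compound 1 at 4000 nM, and no shift beyond the usual scatter from that level is expected. Compound 3 is estimated at 5000 nM, with an expected range from 1500 nM to 20000 nM.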

Compound 3, half-maximal inhibitory concentration: 2000 nM
Estimate against measurement, compound 3: 2.5-fold (0.40 log units) above, within the range that was stated.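

No step can be read between compound 2 and compound 3: only compound 3 carries a number. What 2-benzamidoethyl in place of 4-fluorophenyl does to the cytotoxic strength therefore stays open, and no further data offer an explanation for the value of compound 3.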